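A Methyl on the Ring Nitrogen: Compound 3 to Compound 4

This account rests on a few compounds, and the source may have more. Where it says the series, first, only, none or still open, it means among the compounds named here.

Measured so far in a functional assay on A549 cells (Homo sapiens) for inhibition, read by MTT assay, with a stated time of 72 h; a lower number here means a stronger inhibitor, a higher number a weaker inhibitor:
compound 1 `CN(c1ccc(Oc2ncnc3ccsc23)cc1)c1nccc(N2CCc3ccccc3C2)n1` gives 16200 nM
compound 2 `c1ccc2c(c1)CCN(c1ccnc(Nc3ccc(Oc4ncnc5ccsc45)cc3)n1)C2` gives 17000 nM
compound 3 `c1ccc2c(c1)CCN(c1ccnc(Nc3ccc(Oc4ncnc5sccc45)cc3)n1)C2` gives 6750 nM

Compound 3 has the lowest number of the three in this assay. Its core differs from that of compound 2 as a group of 9 heavy atoms (6 carbon, 2 nitrogen, 1 sulfur; one five-membered aromatic ring with 1 hetero atom, one six-membered aromatic ring with 2 hetero atoms) in place of a group of 9 heavy atoms (6 carbon, 2 nitrogen, 1 sulfur; one five-membered aromatic ring with 1 hetero atom, one six-membered aromatic ring with 2 hetero atoms), on an oxygen on an aromatic ring, and that change made the step of a 2.5-fold lower number from compound 2 to compound 3 (0.40 log units; beyond the scatter). The other change seen among these compounds is methyl in place of hydrogen on a nitrogen on an aromatic ring, which made the step of a 1.0-fold lower number from compound 2 to compound 1 (0.02 log units; within the scatter).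

Compound 4 `CN(c1ccc(Oc2ncnc3sccc23)cc1)c1nccc(N2CCc3ccccc3C2)n1` is not yet measured. It differs from compound 3 as methyl in place of hydrogen on a nitrogen on an aromatic ring, the same change as from compound 2 to compound 1, on the same kind of place. Compound 4 is expected to give about 6800 nM in this assay, because a 1.0-fold lower number from compound 2 to compound 1 (0.02 log units; within the scatter) lies within the scatter. The expected step is a 1.0-fold higher number from compound 3 to compound 4 (0.00 log units; within the scatter). The estimate is expected to fall between 3500 nM and 13500 nM.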

Compound 4, half-maximal inhibitory concentration: 6390 nM
For compound 4 the middle estimate is 1.1-fold (0.03 log units) above the measured one; the measured number falls inside the stated range.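

In this assay, methyl in place of hydrogen on the nitrogen gave a 1.1-fold lower number from compound 3 to compound 4 (0.02 log units; within the scatter) and matched the step seen on the other core: the same change on two cores in this assay, a 1.0-fold lower number (0.02 log units; within the scatter) from compound 2 to compound 1 and a 1.1-fold lower number (0.02 log units; within the scatter) from compound 3 to compound 4, 1.0-fold (0.00 log units) apart, within the scatter of two such steps. The exchange of the group on the oxygen also carried over, giving a 2.5-fold lower number from compound 1 to compound 4 (0.40 log units; beyond the scatter) and agreeing with its earlier counterpart: the same change on two cores in this assay, a 2.5-fold lower number (0.40 log units; beyond the scatter) from compound 2 to compound 3 and a 2.5-fold lower number (0.40 log units; beyond the scatter) from compound 1 to compound 4, 1.0-fold (0.00 log units) apart, within the scatter of two such steps. These two pairs show both changes carrying over between these cores in this assay, but they do not show that either change would behave the same way on any other core, nor do they explain why.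

On these data alone, it remains open whether ethyl or a longer chain on that nitrogen would also leave the number within the scatter. As far as these compounds go, the effect of an amine or a carboxylic acid elsewhere on the shared core also remains open.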